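The source may report more compounds than this note shows. Statements on the series, on what has been measured and on what is new or still open speak of the compounds shown alone.

In a functional assay on ECa-109 cells for inhibition, with ECa-109 cell line (Homo sapiens) as the target, read by sulforhodamine B assay (a higher number here means a weaker inhibitor, a lower number a stronger inhibitor), compound 1 (`O=C1C=C(NCc2ccccc2)C(=O)c2c1nc1n2[C@H]2OC[C@@H](O)[C@H]2OC1`) reads > 8000 nM as a limit of the assay and not a number. Going by the values given here, compound 2 (`O=C1C=C(Nc2cccc(F)c2)C(=O)c2c1nc1n2[C@H]2OC[C@@H](O)[C@H]2OC1`) gives 7030 nM as the only true number so far. Next comes compound 3 (`COc1ccccc1NC1=CC(=O)c2nc3n(c2C1=O)[C@H]1OC[C@@H](O)[C@H]1OC3`), with 2-methoxyphenyl in place of 3-fluorophenyl on an amine nitrogen. Among the compounds with values here, only one measured step bears on this nitrogen (an at least 1.1-fold lower number from compound 1 to compound 2 (0.05 log units; that floor lies within the scatter)), where 3-fluorophenyl replaced benzyl. That step stays within the scatter, so no clear change in either direction is expected in this assay for compound 3, although this single step is thin support. The estimated step for compound 3 (a 1.2-fold lower number from compound 2 to compound 3 (0.07 log units; within the scatter)) stays within the scatter. The estimate for compound 3 is 6000 nM with an expected range (2500 nM to 12000 nM).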

Compound 3, half-maximal inhibitory concentration: > 4000 nM
Compound 3 ended at the assay's limit; the forecaster's own chance of this, stated with the estimate: 35%; the middle value lies beyond the limit too.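

In this assay, compound 3 gives only a limit, and neither its step from compound 2 nor its step from compound 1 can be read. The compounds shown leave open whether 2-methoxyphenyl on the amine nitrogen differs at all from 3-fluorophenyl or benzyl.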